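From Compound 1 to Compound 4: An Expected Gain

The compounds below may be only part of what the source reports. "The series", "measured", "known", "first", "only" and "open" are said of these compounds alone.

compound 1, `Nc1ccccc1-c1cnc(C(=O)CCCCCCc2ccccc2)o1`, 750 nM
compound 2, `Nc1cccc(-c2cnc(C(=O)CCCCCCc3ccccc3)o2)c1`, 19 nM
compound 3, `COC(=O)c1cccc(-c2cnc(C(=O)CCCCCCc3ccccc3)o2)c1`, 12 nM

In an assay (Rattus norvegicus) for inhibition of Fatty-acid amide hydrolase 1 (Homo sapiens) (a lower number here means a stronger inhibitor, a higher number a weaker inhibitor), compound 1 gives 750 nM, the highest of the three numbers measured. The nearest number is that of compound 2, reached by the step of a 39-fold lower number from compound 1 to compound 2 (1.60 log units; beyond the scatter). Compound 3 lies further still: it gives 12 nM, against the value of compound 1. The step of a 1.6-fold lower number from compound 2 to compound 3 (0.20 log units; within the scatter) shows that exchanging the group on the 3-position of the phenyl ring hardly changes the number.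

Compound 4, `NC(=O)c1cccc(-c2cnc(C(=O)CCCCCCc3ccccc3)o2)c1`, has not yet been measured in this assay. It differs from compound 1 by 3-carbamoylphenyl in place of 2-aminophenyl on an aromatic carbon. For the measured compounds named here, two measured steps bear on this change. The step of a 39-fold lower number from compound 1 to compound 2 (1.60 log units; beyond the scatter) shows that moving the group from the 2-position to the 3-position brings a large drop, and the step of a 1.6-fold lower number from compound 2 to compound 3 (0.20 log units; within the scatter) shows that a different group in the 3-position, here a carbonyl-bearing one, leaves the number where it is. Compound 4 carries another carbonyl-bearing group in the 3-position, so a large step downward is expected for compound 4, close to the size of a 50-fold lower number from compound 1 to compound 4 (1.70 log units; beyond the scatter). Compound 4 is therefore estimated at 15 nM, within a range from 5 nM to 50 nM.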

Compound 4, inhibition constant: 6 nM
The estimate for compound 4 lay 2.5-fold (0.40 log units) above the measured number; the measured number falls inside the stated range.
By their numbers in this assay, from the lowest: compounds 4, 3 and 2 (each within the scatter of the next, the first and the last beyond it); then compound 1.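

In this assay the step of a 130-fold lower number from compound 1 to compound 4 (2.10 log units; beyond the scatter) shows that 3-carbamoylphenyl in place of 2-aminophenyl, on the aromatic carbon next to the ring oxygen, is tolerated and gives a large change in the number, so the drop seen with the 3-aminophenyl and methoxycarbonyl compounds extends to a third group. The step of a 2.0-fold lower number from compound 3 to compound 4 (0.30 log units; within the scatter) stays within the scatter, so amino in place of methoxy on the carbonyl carbon does not separate the amide from the ester, whereas the step of a 3.2-fold lower number from compound 2 to compound 4 (0.50 log units; beyond the scatter) lies beyond the scatter, a modest difference and the first among these groups on the phenyl ring that the data can distinguish, even though compound 3 cannot be told apart from either of its neighbours. Nothing shown here gives a reason for any of these differences.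

The compounds shown leave open how a carboxylic acid or a nitrile in place of the carbamoyl group would compare on the same ring. They also leave open how much of the step from compound 1 belongs to the carbamoyl group itself, since a 2-carbamoylphenyl compound does not stand among them.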